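A few compounds are considered here, and "the series" means these few. Any claim that something is new, unique, unknown or untested is made for them only; others in the source may bear on it.

Working notes on the series.

Compound 1 `COc1cc(/C=C/C(=O)c2cccc(-n3cc(-c4ccccc4)[nH]c3=O)c2)ccc1O` sits in the middle of the numbers gathered so far. In a functional assay on SNB-19 cells (Homo sapiens) for inhibition (on this read-out higher numbers stand for weaker inhibition of growth and lower numbers for stronger inhibition of growth), compound 1 gives 2960 nM. Compound 3 `COc1cc(/C=C/C(=O)c2cccc(-n3cc(-c4ccccc4)[nH]c3=O)c2)cc(OC)c1OC`, with two further methoxy groups on the chain aryl, gives 2350 nM in this assay, a number that lies within the scatter of compound 1. Within the data shown here, compound 2 `O=C(/C=C/c1cccc(O)c1)c1cccc(-n2cc(-c3ccccc3)[nH]c2=O)c1` gives 10900 nM; the one step recorded, a 3.7-fold higher number from compound 1 to compound 2 (0.57 log units; beyond the scatter), is the only change in the set that reaches beyond the scatter, and it concerns the aryl on the double-bonded chain.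

Compound 4 `COc1ccc(-c2cn(-c3cccc(C(=O)/C=C/c4ccc(O)c(OC)c4)c3)c(=O)[nH]2)cc1` is the next member to be measured. It differs from compound 1 by a single change: methoxy in place of hydrogen on an aromatic carbon, on the phenyl carried by the shared core rather than on the chain aryl. Among the measured compounds shown here, no measured step touches that phenyl, so nothing recorded bears directly on this change. For the measured compounds named here, the only guidance is indirect: adding methoxy groups elsewhere, as in compound 3, left the number within the scatter of compound 1, whereas the one step beyond the scatter involved loss of the hydroxyl and methoxy pair on the chain side. A step no larger than the scatter is therefore expected, with no direction to be read from the data; the anticipated step is a 1.1-fold lower number from compound 1 to compound 4 (0.04 log units; within the scatter). Compound 4 is estimated at 2700 nM in this assay, within a range of 1100 nM to 7000 nM.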

Compound 4, concentration for 50% growth inhibition: 5840 nM
Beside the measured number, compound 4's estimate is 2.2-fold (0.34 log units) below it; the measured number falls inside the stated range.
By their numbers in this assay, from the lowest: compounds 3, 1, 4 and 2 (each within the scatter of the next, the first and the last beyond it).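

In this assay, the first change recorded on the phenyl carried by the shared core, phenyl to 4-methoxyphenyl, gives a 2.0-fold higher number from compound 1 to compound 4 (0.30 log units; within the scatter). Among these compounds, this place, para to a large group, therefore takes a methoxy in place of hydrogen without a step beyond the scatter, whereas the one step beyond it on record remains the change on the chain aryl, a 3.7-fold higher number from compound 1 to compound 2 (0.57 log units; beyond the scatter) on this read-out. No supporting data bear on this result, so the reading stops at the numbers.

The compounds shown leave open how a chlorine atom, an amine or a carboxylic acid at this same place on the phenyl would read in this assay, since a single substituent cannot show whether the tolerance extends to groups of another kind. On these data alone, it also remains open whether methoxy on the other carbons of this ring would read the same, and whether the phenyl to 4-methoxyphenyl change would give a similar step when paired with the chain aryl of compound 2 or compound 3.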